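The compounds below may be only part of what the source reports. "The series", "measured", "known", "first", "only" and "open" are said of these compounds alone.

In a functional assay on DU-145 cells (Homo sapiens) for inhibition, read by MTT assay, with a stated time of 48 h (a higher number here means a weaker inhibitor, a lower number a stronger inhibitor), compound 1 `Cn1c(/C=C2\SC(=O)N(CC(=O)Nc3cc(C(C)(C)C)on3)C2=O)nc2ccccc21` gives 31400 nM. Compound 2 `CCn1c(/C=C2\SC(=O)N(CC(=O)N3CCCCC3)C2=O)nc2ccccc21` reads > 50000 nM, which is a limit and not a number. Compound 3 `CCn1c(/C=C2\SC(=O)N(CC(=O)Nc3cc(C(C)(C)C)on3)C2=O)nc2ccccc21` reads > 50000 nM, which is also a limit. Compound 3 therefore stands at the limit of > 50000 nM in this assay, at which 2 of the 3 values shown sit, with no number of its own.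

Compound 4 `CCn1c(/C=C2\SC(=O)N(CC(=O)N3CCCC3)C2=O)nc2ccccc21` departs from compound 3 by pyrrolidin-1-yl in place of (5-(tert-butyl)-1,2-oxazol-3-yl)amino on a carbonyl carbon, with pyrrolidin-1-yl in place of (5-(tert-butyl)-1,2-oxazol-3-yl)amino on a carbonyl carbon. Among the compounds with values here, two measured steps bear on this. The nearer one, at the same carbonyl carbon, is a step that the two limits leave unreadable from compound 2 to compound 3. The other is an at least 1.5-fold higher number from compound 1 to compound 3 (0.20 log units; that floor lies within the scatter), which concerns a methyl on a saturated chain carbon bound to an aromatic nitrogen, a part that this change leaves alone. Neither gives a readable size for the change at the carbonyl carbon. Compound 2, which carries piperidin-1-yl there, offers the closest guide, and it sits at the same limit as compound 3.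

The expected result is a number no higher from compound 3 to compound 4 (the limit leaves the size open), with no shift beyond the scatter foreseen in either direction. For compound 4 the estimated value is 50000 nM, within an expected range of 25000 nM to 100000 nM, and a report of only a limit is the likeliest outcome.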

Compound 4, half-maximal inhibitory concentration: 45100 nM
Compound 4: the middle estimate sits 1.1-fold (0.04 log units) above what was measured; low and high end bracket the measured number.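

In this assay, within the data shown here, compound 4 gives 45100 nM, so pyrrolidin-1-yl on the carbonyl carbon provides the first actual number among compound 2, compound 3 and compound 4. The new readings are an at least 1.1-fold lower number from compound 3 to compound 4 (0.04 log units; that floor lies within the scatter) and an at least 1.1-fold lower number from compound 2 to compound 4 (0.04 log units; that floor lies within the scatter); each is only a floor, so neither change is shown to move the number beyond the scatter, and the true size of each remains unknown. The step between compound 2 and compound 3 still cannot be read, as each of them remains a limit and not a number: the limit of > 50000 nM in this assay, at which 2 of the 4 values shown sit.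

The compounds shown leave open whether a morpholin-4-yl group or a longer chain ending in a carboxylic acid on this carbonyl carbon would give a clearly different number. They also leave open whether methyl in place of hydrogen on the saturated chain carbon bound to the aromatic nitrogen would change the number when pyrrolidin-1-yl is present.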